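The source may hold more compounds than are shown below. What is called first, only, known or untested is meant among the compounds shown, and "the series" means these compounds.

Of the compounds shown here, three with a shared core have been measured in an in vitro functional assay on cells for agonist activity at Bombesin receptor subtype-3 (Mus musculus), read by luminescence and calcium flux; a lower number here means that less compound is needed, a higher number that more compound is needed for the effect. Compound 1 `O=C(O)c1ccccc1-c1ccc(CCc2ncc(Cc3ccccc3F)[nH]2)cc1` carries a 2-fluorobenzyl group and gives 9.5 nM. Compound 2 `CC(C)(C)CCc1cnc(CCc2ccc(-c3ccccc3C(=O)O)cc2)[nH]1` carries a 3,3-dimethylbutyl group at the same place and gives 6.2 nM. Compound 3 `CC(C)(C)c1cnc(CCc2ccc(-c3ccccc3C(=O)O)cc2)[nH]1` carries a tert-butyl group there and gives 2750 nM. Compound 3 therefore stands at the highest of the three numbers, needing far more compound than either of the others: a 290-fold higher number from compound 1 to compound 3 (2.46 log units; beyond the scatter) and a 440-fold higher number from compound 2 to compound 3 (2.65 log units; beyond the scatter), whereas the two low-number compounds sit close together, a 1.5-fold lower number from compound 1 to compound 2 (0.19 log units; within the scatter).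

Compound 4 `O=C(O)c1ccccc1-c1ccc(CCc2ncc(Cc3ccccc3)[nH]2)cc1` has not yet been measured. It arises from compound 3 by one change, (benzyl in place of tert-butyl on an aromatic carbon). The two steps that bear on this are those leading into compound 3, each of which shows that putting a small tert-butyl group at this position in place of a longer group costs a great deal. Moving back from tert-butyl to benzyl reverses the first of them, and compound 1 differs from compound 4 only in a fluorine, so compound 4 is expected to fall close to compound 1. Compound 4 is estimated at 12 nM, within 4 nM to 40 nM, an expected step of a 230-fold lower number from compound 3 to compound 4 (2.36 log units; beyond the scatter).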

Compound 4, half-maximal effective concentration: 11 nM
The estimate for compound 4 lay 1.1-fold (0.04 log units) above the measured number; low and high end bracket the measured number.
By their numbers in this assay, from the lowest: compounds 2, 1 and 4 (each within the scatter of the next); then compound 3.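

In this assay, the large penalty seen with tert-butyl is undone by benzyl on this aromatic carbon of the five-membered ring, bringing the number back to the level of compound 1 and compound 2 (a 250-fold lower number from compound 3 to compound 4 (2.40 log units; beyond the scatter)). The fluorine of compound 1 now proves to carry no measurable weight, since hydrogen in its place leaves the number within the scatter (a 1.2-fold higher number from compound 1 to compound 4 (0.06 log units; within the scatter)). The aromatic ring of the benzyl group is also not required, as the phenyl end of compound 4 and the neopentyl end of compound 2 cannot be told apart (a 1.8-fold higher number from compound 2 to compound 4 (0.25 log units; within the scatter)), so among these four compounds only the tert-butyl of compound 3 stands out.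

Nothing shown here explains why tert-butyl behaves so differently from benzyl and 3,3-dimethylbutyl. As far as these compounds go, it also remains open how a plain ethyl or propyl chain at this carbon would behave, which would help show how much of a chain is needed, and whether an amine or a hydroxyl on the benzyl ring would keep the number low.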